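The compounds below may be only part of what the source reports. "The series", "measured", "known", "first", "only" and "open" are said of these compounds alone.

In a functional assay on MIA PaCa-2 cells (Homo sapiens) for inhibition, read by MTT assay, with a stated time of 72 h (on this read-out higher numbers stand for weaker inhibition of growth and lower numbers for stronger inhibition of growth), compound 2 `O=S(=O)(NCCCNCc1cccc(Cl)c1)c1cc(C(F)(F)F)cc(C(F)(F)F)c1` gives 4400 nM, the lowest of the two numbers measured, though the nearest compound sits within the scatter of it. That neighbour, compound 1 `O=S(=O)(NCCCNCc1ccc(Cl)c(C(F)(F)F)c1)c1cc(C(F)(F)F)cc(C(F)(F)F)c1`, gives 7400 nM in this assay, and the change between them, a 1.7-fold lower number from compound 1 to compound 2 (0.23 log units; within the scatter), is too small to count as a real difference. Compound 3 `O=S(=O)(NCCCNCc1ccc(Cl)cc1)c1cc(C(F)(F)F)cc(C(F)(F)F)c1` has not yet been measured. It differs from compound 2 only by 4-chlorophenyl in place of 3-chlorophenyl on a saturated chain carbon bound to an amine nitrogen; the two share every atom and differ solely in how they are joined. Among the compounds with values here, the one measured step that bears on this pair, from compound 1 to compound 2, moved the chlorine-bearing ring's substitution without a change beyond the scatter, so for compound 3 in this assay no step beyond the scatter is expected in either direction, an anticipated shift of a 1.0-fold higher number from compound 2 to compound 3 (0.01 log units; within the scatter). Compound 3 is therefore estimated at 4500 nM, with a range from 2000 nM to 10000 nM.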

Compound 3, concentration for 50% growth inhibition: 2800 nM
Estimate against measurement, compound 3: 1.6-fold (0.21 log units) above; low and high end bracket the measured number.
By their numbers in this assay, from the lowest: compounds 3, 2 and 1 (each within the scatter of the next, the first and the last beyond it).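

In this assay, moving the chlorine from 3-chlorophenyl to 4-chlorophenyl on a saturated chain carbon bound to an amine nitrogen gives a 1.6-fold lower number from compound 2 to compound 3 (0.20 log units; within the scatter), so the two isomers cannot be told apart on this read-out. Hydrogen in place of trifluoromethyl on an aromatic carbon gives a 2.6-fold lower number from compound 1 to compound 3 (0.42 log units; beyond the scatter), the first modest difference in this set, while compound 2, which also lacks the trifluoromethyl group, stays within the scatter of compound 1. Nothing offered here accounts for either step. The compounds shown leave open whether bromine or a methoxy group in place of the chlorine of compound 3 would keep this level of growth inhibition. They also leave open what a longer chain in the shared core would do.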